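From 2-(furan-3-yl)ethyl to formyl on compound 3

A few compounds are considered here, and "the series" means these few. Any claim that something is new, unique, unknown or untested is made for them only; others in the source may bear on it.

compound 1 `CC1=CC(=O)[C@H]2C(C)(C)CCC[C@]2(C)[C@H]1/C=C/C1=C[C@H]2O[C@H]1[C@H]1C(=O)C=CC(=O)[C@H]12` gives 14.1 ug/mL
compound 2 `CC1(C)CCC[C@]2(C)[C@@H](/C=C/c3ccoc3)C(CO)=CC(=O)[C@@H]12` gives 26.2 ug/mL
compound 3 `CC1=CC(=O)[C@H]2C(C)(C)CCC[C@]2(C)[C@H]1CCc1ccoc1` gives 87 ug/mL

In a functional assay on HL-60 cells (Homo sapiens) for cytotoxicity, with a stated time of 24 h (a higher number here means a weaker inhibitor, a lower number a stronger inhibitor), compound 3 stands highest of the three at 87 ug/mL and is the weakest inhibitor here, with its gaps to compound 2 and compound 1 both beyond the scatter. Compound 4 `CC1=CC(=O)[C@H]2C(C)(C)CCC[C@]2(C)[C@H]1C=O` differs from it by carrying formyl in place of 2-(furan-3-yl)ethyl on a saturated ring carbon. No two measured compounds differ in one place alone, so the size of this change in this assay is not shown directly. Among the measured compounds shown here, the only guide is the spread of the numbers: compound 3 sits at the top at 87 ug/mL while every other measured compound lies lower, down to compound 1 at 14.1 ug/mL. The expected change is a modest move to a lower number (a 1.7-fold lower number from compound 3 to compound 4 (0.24 log units; within the scatter)) and it may stay within the scatter. For compound 4 the estimated value is 50 ug/mL with an expected range from 15 ug/mL to 150 ug/mL in this measurement.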

Compound 4, half-maximal inhibitory concentration: 39.7 ug/mL
Compound 4: the middle estimate sits 1.3-fold (0.10 log units) above what was measured; low and high end bracket the measured number.
By their numbers in this assay, from the lowest: compounds 1, 2 and 4 (each within the scatter of the next, the first and the last beyond it); then compound 3.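

Among the compounds shown here, the first step in one place alone shows that this position responds to the group it carries: in this assay, replacing 2-(furan-3-yl)ethyl with formyl on the saturated ring carbon gives a 2.2-fold lower number from compound 3 to compound 4 (0.34 log units; beyond the scatter). The change is modest but lies beyond the scatter, so the five-membered aromatic ring and its two-carbon link are not needed on this core to retain cytotoxicity in these cells, and the much smaller formyl does better here. No evidence is available on what lies behind this step.

From the compounds shown here alone, what remains open is whether the carbonyl of formyl matters or whether the shorter group alone accounts for the step, which a plain methyl or ethyl on the same carbon would help to separate. Going by these compounds, it is also open how a carboxylic acid or an aminomethyl group would behave at this position.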